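The source may report more compounds than this note shows. Statements on the series, on what has been measured and on what is new or still open speak of the compounds shown alone.

Working notes on the series

The shared core carries a benzyl sulfoxide and a pyridyl amide; the compounds differ only in the substitution of the benzyl ring. Compound 1 `COc1ccc(C[S+]([O-])c2ncccc2C(=O)Nc2ccncc2)c(OCCO)c1` bears a 2-hydroxyethoxy group, and in an ADME assay (on this read-out lower numbers stand for a shorter-lived compound and higher numbers for a longer-lived compound), compound 1 gives 1.78 h. Compound 2 `COc1cc(OC)c(C[S+]([O-])c2ncccc2C(=O)Nc2ccncc2)cc1Br` gives 28.8 h in this assay, so compound 1 stands lowest of the two numbers on record, well beyond the scatter below compound 2. Compound 3 `COc1cc(OC)c(C[S+]([O-])c2ncccc2C(=O)Nc2ccncc2)c(OC)c1` is reported in this assay at < 0.03 h, which is a limit of the assay and not a number (the limit of < 0.03 h in this assay, at which 1 of the 3 values shown sits).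

Compound 4 `COc1ccc(C[S+]([O-])c2ncccc2C(=O)Nc2ccncc2)c(OCCF)c1` is not yet measured. It differs from compound 1 in one place: fluoro in place of hydroxy on a saturated chain carbon, two bonds along the chain from an oxygen on an aromatic ring. Among the measured compounds shown here, no pair of measured compounds differs in just one place, so the size of this step can only be guessed. The expectation for the step from compound 1 to compound 4 in this assay is a 1.4-fold higher number from compound 1 to compound 4 (0.15 log units; within the scatter), a small move toward a longer-lived compound that may well fall within the scatter. Compound 4 is therefore estimated at 2.5 h, with a range from 0.8 h to 8 h.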

Compound 4, half-life: 3.3 h
Estimate against measurement, compound 4: 1.3-fold (0.12 log units) below; the range from low to high includes it.
By their numbers in this assay, from the lowest: compounds 1 and 4 (each within the scatter of the next); then compound 2. At a limit, below all of these: compound 3.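

Among the compounds shown here, this step is the first that can be read at a single place: in this assay, fluoro in place of hydroxy on a saturated chain carbon, two bonds along the chain from an oxygen on an aromatic ring, gives a 1.9-fold higher number from compound 1 to compound 4 (0.27 log units; within the scatter). At this position, then, the 2-hydroxyethoxy and 2-fluoroethoxy groups cannot be told apart on this read-out, even though the hydrogen-bond donor and acceptor counted on the hydroxy leave and fluoro brings neither. Nothing shown here gives a cause for this step.

On these data alone, whether the chain end would read the same with an amine, a carboxylic acid or a longer chain remains open. Compound 2 and compound 3 differ from compound 1 in more than one place, so their values cannot be tied to this position.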